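What a fluoro group might do to compound 1

The source may hold more compounds than are shown below. What is called first, only, known or untested is meant among the compounds shown, and "the series" means these compounds.

Compound 1 `C/C(=N/NC(=S)Nc1ccccc1)c1ccccn1` is tested in a functional assay on T98G cells (Homo sapiens) for cytotoxicity, read by MTT assay, with a stated time of 48 h (a lower number here means a stronger inhibitor, a higher number a weaker inhibitor), where compound 1 gives 6.81 nM. Two close relatives are also measured: compound 2 `CC(=NNC(=S)Nc1ccccc1)c1ccccn1` gives 6.8 nM and compound 3 `C/C(=N/NC(=S)Nc1ccccc1[N+](=O)[O-])c1ccccn1` gives 6.61 nM. These three numbers lie within the scatter of one another, so compound 1 holds no separate rank among them.

The open question is compound 4 `C/C(=N/NC(=S)Nc1ccc(F)cc1)c1ccccn1`, which differs from compound 1 in one place: fluoro in place of hydrogen on an aromatic carbon. The change is fluoro in place of hydrogen on an aromatic carbon, para to a large group.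

Two measured steps can be consulted. The first, a 1.0-fold lower number from compound 1 to compound 2 (0.00 log units; within the scatter), joins two drawings with the same atoms and bonds and concerns only how a double bond is drawn, so it offers no guide to a new group. The closer precedent is nitro in place of hydrogen on an aromatic carbon, a 1.0-fold lower number from compound 1 to compound 3 (0.01 log units; within the scatter), so no step beyond the scatter is expected in this assay for the fluoro change. This rests on a single substitution. The range stays fairly wide. The estimate is a 1.0-fold lower number from compound 1 to compound 4 (0.01 log units; within the scatter), with no firm direction expected. For compound 4 the estimated value is 6.6 nM, with an expected range from 3.5 nM to 12 nM.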

Compound 4, half-maximal inhibitory concentration: 17 nM
Compound 4: middle estimate off by 2.6-fold (0.41 log units), on the low side; measured number outside the range, above it.
By their numbers in this assay, from the lowest: compounds 3, 2 and 1 (each within the scatter of the next); then compound 4.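

In this assay, for the compounds shown here, the ring that carries the new group turns out not to be indifferent to substitution, since the fluoro change gives the only step in this set that lies beyond the scatter (a 2.5-fold higher number from compound 1 to compound 4 (0.40 log units; beyond the scatter)), and it runs toward a weaker inhibitor. Swapping one hydrogen for one fluorine atom, para to a large group, adds a single heavy atom, yet that moves the number, while the nitro step stayed within the scatter (a 1.0-fold lower number from compound 1 to compound 3 (0.01 log units; within the scatter)), so the result of one substitution on this ring cannot simply be carried over to another. Nothing measured here explains why the fluoro change gives a higher number.

A single compound cannot show whether this shift belongs to fluoro itself or to any group placed para to a large group, and a chloro, methyl, methoxy or amine group at the same place would help to separate those two readings. Going by these compounds, it also remains open whether fluoro at other places on this six-membered aromatic ring would give a similar step, a smaller one or none beyond the scatter.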